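Dropping a dimethylamino group from an amidoxime hydrazone

A few compounds are considered here, and "the series" means these few. Any claim that something is new, unique, unknown or untested is made for them only; others in the source may bear on it.

Measured so far:
- compound 1 `N=C(NO)N/N=C/c1ccccc1Cl`: > 100000 nM
- compound 2 `CN(C)c1ccc(/C=N/NC(=N)NO)cc1`: > 100000 nM

In an ADME assay on Vero cells (Chlorocebus sabaeus) for cytotoxicity (on this read-out higher numbers stand for lower toxicity in this test and lower numbers for higher toxicity in this test), compound 1 gives > 100000 nM, which is a limit of the assay rather than a number. Compound 2 likewise gives > 100000 nM, again a limit. Compound 2 therefore stands where both of the values shown stand, as summed up by the limit of > 100000 nM in this assay, at which 2 of the 2 values shown sit.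

The next step leads to compound 3 `N=C(NO)N/N=C/c1ccccc1`. Compared with compound 2 the change is hydrogen in place of dimethylamino on an aromatic carbon. Going by the values given here, nothing measured so far shows such a change moving this read-out, and both values seen sit at the same limit, so the step from compound 2 to compound 3 in this assay is expected to be none beyond the scatter, as a number no higher from compound 2 to compound 3 (the limit leaves the size open) expresses it. Compound 3 is estimated at 100000 nM, between 50000 nM and 200000 nM, most likely again reported only as a limit.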

Compound 3, half-maximal cytotoxic concentration: > 100000 nM
Compound 3 was reported as a limit; the forecaster's own chance of this, stated with the estimate: 80%; the middle value sits exactly at the limit.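

No step can be read from compound 1 or from compound 2 to compound 3, as all three compounds sit at one limit: the limit of > 100000 nM in this assay, at which 3 of the 3 values shown sit.

The compounds shown leave open whether hydrogen, chloro or dimethylamino on the aromatic ring changes this read-out at all.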